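The compounds below may be only part of what the source reports. "The series", "measured", "known", "first", "only" and "open" are said of these compounds alone.

Working notes on the series.

Compound 2 `Cc1ccc(Nc2ncc3c(n2)N(C)C(=O)N(c2cc(NC(=O)c4cccc(C(F)(F)F)c4)ccc2C)C3)cc1` gives 8000 nM in an ADME assay on BaF3 cells (Mus musculus) for antiproliferative activity, read by CellTiter-Glo and CCK-8 assay, with a stated time of 72 h; a higher number here means a weaker inhibitor of growth, a lower number a stronger inhibitor of growth. Going by the values given here, of the three numbers measured so far it stands second highest; compound 3 `Cc1ccc(NC(=O)c2cccc(C(F)(F)F)c2)cc1N1Cc2cnc(O[C@H]3CCN(C(=O)OC(C)(C)C)C3)nc2N(C)C1=O` gives 8380 nM, which lies within the scatter of compound 2, while compound 1 `Cc1ccc(Nc2ncc3c(n2)N(C)C(=O)N(c2cc(NC(=O)c4cccc(C(F)(F)F)c4)ccc2C)C3)cc1C` gives 3760 nM, the lowest of the three. Among the compounds with values here, the one single-point step among the measured compounds runs a 2.1-fold higher number from compound 1 to compound 2 (0.33 log units; beyond the scatter), a modest loss on taking a methyl off the ring.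

Compound 4 `CNc1cc(Nc2ncc3c(n2)N(C)C(=O)N(c2cc(NC(=O)c4cccc(C(F)(F)F)c4)ccc2C)C3)ccc1C` differs from compound 2 by methylamino in place of hydrogen on an aromatic carbon. Within the data shown here, no measured pair shows the effect of a methylamino group on this ring, so the only bearing is the opposite direction of the step from compound 1 to compound 2: putting a small group onto the same ring restored a modest amount of growth inhibition there. A step of similar size, toward a lower number, is therefore expected, though with wide uncertainty. For compound 4 the estimate in this assay is 4000 nM, with a range from 1300 nM to 12000 nM; this corresponds to an expected step of a 2.0-fold lower number from compound 2 to compound 4 (0.30 log units; within the scatter).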

Compound 4, concentration for 50% growth inhibition: > 10000 nM
Compound 4 ended at the assay's limit (the forecaster's own chance of this, stated with the estimate: 5%); at least 2.5-fold (0.39 log units) between middle value and limit.
By their numbers in this assay, from the lowest: compound 1; then compounds 2 and 3 (each within the scatter of the next). At a limit, above all of these: compound 4.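

In this assay compound 4 stands at a limit of the assay, not at a number: the limit of > 10000 nM in this assay, at which 1 of the 4 values shown sits.

Methylamino on this aromatic carbon, ortho to a methyl group, shows no gain in growth inhibition over hydrogen, with an at least 1.2-fold higher number from compound 2 to compound 4 (0.09 log units; that floor lies within the scatter), and that floor leaves the real size of the change unknown. Against methyl on the same carbon the loss can be read, with an at least 2.6-fold higher number from compound 1 to compound 4 (0.42 log units; beyond the scatter), so the modest gain seen with methyl at this position does not carry over to methylamino.

The compounds shown leave open how a plain amine, a methoxy group or a fluorine on this carbon would compare with methyl and methylamino. They also leave open how far past its limit compound 4 lies.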